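Swapping the Anilide Aryl Group Once More

The compounds below may be only part of what the source reports. "The series", "measured", "known", "first", "only" and "open" are said of these compounds alone.

Among the measured compounds shown here, compound 2 `Cc1cc(Br)ccc1NC(=O)COc1ccc2cc(/C=C3/SC(=O)NC3=O)ccc2c1` stands beside compound 1 `COc1cccc(NC(=O)COc2ccc3cc(/C=C4/SC(=O)NC4=O)ccc3c2)c1` on the numbers measured so far in an assay on isolated protein for inhibition of histone deacetylase 8 (Homo sapiens), with a stated time of 1 h; on this read-out lower numbers stand for stronger inhibition and higher numbers for weaker inhibition: compound 2 gives 7400 nM, while compound 1 gives 7600 nM, and the gap between the two lies within the scatter. For the measured compounds named here, the only measured step that bears on the new change is a 1.0-fold lower number from compound 1 to compound 2 (0.01 log units; within the scatter), an exchange of one aryl group for another on the amide-type nitrogen that left the read-out where it was. Compound 3 `O=C(COc1ccc2cc(/C=C3/SC(=O)NC3=O)ccc2c1)Nc1cccc(C(F)(F)F)c1` differs from compound 2 in the same region: 3-(trifluoromethyl)phenyl in place of 4-bromo-2-methylphenyl on an amide-type nitrogen. Since the earlier exchange on that nitrogen produced a 1.0-fold lower number from compound 1 to compound 2 (0.01 log units; within the scatter), no step beyond the scatter is expected in this assay, in either direction. The estimated step is therefore a 1.0-fold higher number from compound 2 to compound 3 (0.01 log units; within the scatter). Compound 3 is expected to give 7500 nM in this assay, with a plausible range from 3500 nM to 16000 nM.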

Compound 3, half-maximal inhibitory concentration: > 50000 nM
Compound 3: a limit, no number; the forecaster's own chance of this, stated with the estimate: 5%; at least 6.6-fold (0.82 log units) between middle value and limit.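

In this assay compound 3 gives a limit and not a number: the limit of > 50000 nM in this assay, at which 1 of the 3 values shown sits.

The earlier exchange on the amide-type nitrogen, a 1.0-fold lower number from compound 1 to compound 2 (0.01 log units; within the scatter), suggested that the aryl group there could be changed with no effect on the read-out, but this does not hold for every aryl group. Among the compounds shown here, replacing 4-bromo-2-methylphenyl with 3-(trifluoromethyl)phenyl gives an at least 6.7-fold higher number from compound 2 to compound 3 (0.82 log units; beyond the scatter), and the single change of trifluoromethyl in place of methoxy on an aromatic carbon gives an at least 6.5-fold higher number from compound 1 to compound 3 (0.81 log units; beyond the scatter).

As far as these compounds go, how far compound 3 lies past its limit cannot be read, so the true size of both steps stays open. Also open, from the compounds shown here alone, is what an amine or a carboxylic acid on that same aromatic carbon would give in this assay.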